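Imidazole substituent variation at the ethoxy position

This account rests on a few compounds, and the source may have more. Where it says the series, first, only, none or still open, it means among the compounds named here.

Measured compounds and values:
Compound 1 `CCOc1nc(CC)n2c1C(CCc1ccc(C(F)(F)F)cc1)N([C@@H](C(=O)NC)c1ccccc1)CC2`: 3980 nM
Compound 2 `CCc1nc(C(C)C)c2n1CCN([C@@H](C(=O)NC)c1ccccc1)C2CCc1ccc(C(F)(F)F)cc1`: 10000 nM
Compound 3 `CCc1nc(C2CC2)c2n1CCN([C@@H](C(=O)NC)c1ccccc1)[C@H]2CCc1ccc(C(F)(F)F)cc1`: 4170 nM

The read-out is a functional assay on CHO cells for antagonist activity at Orexin/Hypocretin receptor type 1 (Homo sapiens), read by FLIPR and calcium flux; a lower number here means a stronger inhibitor, a higher number a weaker inhibitor. Among the three measured compounds, compound 1 gives the lowest number, with compound 3 within the scatter of it and compound 2 beyond the scatter, as a 2.5-fold higher number from compound 1 to compound 2 (0.40 log units; beyond the scatter) shows.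

Compound 4 `CCc1nc(I)c2n1CCN([C@@H](C(=O)NC)c1ccccc1)C2CCc1ccc(C(F)(F)F)cc1` is not yet measured. It differs from compound 1 in one place: iodo in place of ethoxy on an aromatic carbon. For the measured compounds named here, no measured pair in this assay involves iodo at that position, so the only step that bears on the change is a 2.5-fold higher number from compound 1 to compound 2 (0.40 log units; beyond the scatter), where the same ethoxy was replaced at the same position. That step was modest and pointed toward a higher number. The change to iodo is a different group, so the size cannot be carried over directly; the expectation is for a small shift upward or none beyond the scatter, with the range kept wide.

Compound 4 is therefore estimated at 5500 nM, from 2000 nM to 15000 nM, which means an expected step of a 1.4-fold higher number from compound 1 to compound 4 (0.14 log units; within the scatter).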

Compound 4, half-maximal inhibitory concentration: 717 nM
Compound 4: the middle estimate sits 7.7-fold (0.88 log units) above what was measured; the measured number lies below the stated range.
By their numbers in this assay, from the lowest: compound 4; then compounds 1 and 3 (each within the scatter of the next); then compound 2.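

In this assay, for the compounds shown here, this aromatic carbon tolerates more than the earlier compounds showed: iodo in place of ethoxy gives a 5.6-fold lower number from compound 1 to compound 4 (0.74 log units; beyond the scatter), whereas the only earlier step here, a 2.5-fold higher number from compound 1 to compound 2 (0.40 log units; beyond the scatter), ran towards a higher number. Iodo in place of isopropyl gives a 14-fold lower number from compound 2 to compound 4 (1.14 log units; beyond the scatter), so the choice of group at this one position spans a wide range of numbers while the rest of the molecule stays fixed. No supporting data on the origin of these shifts are available, and the steps record only their direction and size.

From the compounds shown here alone, it remains open whether bromo, chloro or a nitrile at this carbon would give numbers close to iodo or whether the shift is particular to iodo. Going by these compounds, it is also open whether the iodo step would hold with a longer chain in place of the ethyl group.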